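The compounds below may be only part of what the source reports. "The series", "measured", "known", "first", "only" and "open" are said of these compounds alone.

Three compounds have values so far in a functional assay on MCF7 cells (Homo sapiens) for antiproliferative activity, read by MTT assay; on this read-out higher numbers stand for weaker inhibition and lower numbers for stronger inhibition

compound 1 `COc1cc(N2C(=O)[C@H](c3cccs3)[C@H]2c2cccc3ccccc23)cc(OC)c1OC` gives 620 nM
compound 2 `COc1ccc([C@@H]2[C@@H](C(O)c3ccsc3)C(=O)N2c2cc(OC)c(OC)c(OC)c2)cc1` gives 990 nM
compound 3 `COc1ccc([C@@H]2C(c3ccsc3)C(=O)N2c2cc(OC)c(OC)c(OC)c2)cc1` gives 60 nM

Compound 1 (620 nM) and compound 2 (990 nM) lie within the usual scatter of each other, so these two numbers cannot be told apart. Compound 3 (60 nM) gives a clearly lower number than compound 1, a gap well beyond the scatter. However, compound 3 differs from compound 1 in more than one place, so that gap says little about any single change.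

The next compound to be tested is compound 4 `COc1cc(N2C(=O)[C@H](c3cccs3)[C@H]2c2ccc3ccccc3c2)cc(OC)c1OC`, which keeps the rest of compound 1 and has naphthalen-2-yl in place of naphthalen-1-yl on a saturated ring carbon. The two compounds have the same atoms, joined differently. Within the data shown here, no measured pair shows this swap on its own, so there is no direct guide. The best anchor is compound 1 at 620 nM in this assay, and no step beyond the scatter is the likeliest outcome, although a larger move in either direction cannot be ruled out. The expected change is small, estimated as a 1.2-fold lower number from compound 1 to compound 4 (0.09 log units; within the scatter) (an expectation only). The estimate for compound 4 is 500 nM (expected range 130 nM to 1900 nM).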

Compound 4, half-maximal inhibitory concentration: 120 nM
Compound 4: middle estimate off by 4.2-fold (0.62 log units), on the high side; measured number outside the range, below it.
By their numbers in this assay, from the lowest: compounds 3 and 4 (each within the scatter of the next); then compounds 1 and 2 (each within the scatter of the next).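

In this assay, replacing naphthalen-1-yl with naphthalen-2-yl on the saturated ring carbon gives a 5.2-fold lower number from compound 1 to compound 4 (0.71 log units; beyond the scatter). Among these compounds, this is the first change that can be read on its own, as no earlier pair differed in only one place, and it shows that this position responds to how the naphthalene is joined, even though the two groups have the same atoms and the same counts of rings, donors and acceptors. No measurement available here explains why the two groups differ.

The compounds shown leave open whether the lower number is particular to naphthalen-2-yl or would also appear with other groups on this carbon, such as a quinolin-3-yl or a biphenyl-4-yl group. They also leave open whether the same swap would give a step of similar size if the thiophen-2-yl group on the core of compound 1 were replaced by another group, such as a benzyl group.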